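Moving Chloro and Methyl Around a Phenyl Ring

The source may hold more compounds than are shown below. What is called first, only, known or untested is meant among the compounds shown, and "the series" means these compounds.

Compound 1 `CC/C(=C(/c1ccc(/C=C/C(=O)O)cc1)c1cc2ccccc2[nH]1)c1ccccc1OC(F)(F)F`: 206 nM
Compound 2 `CC/C(=C(/c1ccc(/C=C/C(=O)O)cc1)c1cc2ccccc2[nH]1)c1cccc(C(F)(F)F)c1`: 325 nM
Compound 3 `CC/C(=C(/c1ccc(/C=C/C(=O)O)cc1)c1cc2ccccc2[nH]1)c1c(C)cccc1Cl`: 30 nM

In a functional assay on MCF7 cells (Homo sapiens) for inhibition (on this read-out lower numbers stand for stronger inhibition and higher numbers for weaker inhibition), compound 3 stands lowest of the three numbers: the step of a 6.9-fold lower number from compound 1 to compound 3 (0.84 log units; beyond the scatter) and the step of an 11-fold lower number from compound 2 to compound 3 (1.03 log units; beyond the scatter) both lie beyond the scatter, so compound 3 is the most potent of the measured set. Compound 4 `CC/C(=C(/c1ccc(/C=C/C(=O)O)cc1)c1cc2ccccc2[nH]1)c1ccc(Cl)c(C)c1` keeps every atom of compound 3 but rearranges the phenyl substituents: 4-chloro-3-methylphenyl in place of 2-chloro-6-methylphenyl on a double-bonded chain carbon bound to a double-bonded chain carbon and a saturated chain carbon.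

Going by the values given here, no measured step covers this rearrangement directly. What the three compounds show is that the two phenyl groups without a substituent at a 2-position or a 6-position, 3-(trifluoromethyl)phenyl in compound 2 and, more weakly, 2-(trifluoromethoxy)phenyl in compound 1, gave higher numbers than 2-chloro-6-methylphenyl; the step of a 1.6-fold higher number from compound 1 to compound 2 (0.20 log units; within the scatter) was within the scatter. Compound 4, with chloro at the 4-position and methyl at the 3-position, resembles compound 2 in pattern more than compound 3, so a loss is expected, estimated as a 6.0-fold higher number from compound 3 to compound 4 (0.78 log units; beyond the scatter). Compound 4 is thus estimated at 180 nM, with a range from 60 nM to 550 nM.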

Compound 4, half-maximal inhibitory concentration: 840 nM
For compound 4 the middle estimate is 4.7-fold (0.67 log units) below the measured one; measured number outside the range, above it.
By their numbers in this assay, from the lowest: compound 3; then compounds 1 and 2 (each within the scatter of the next); then compound 4.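

Compound 3 and compound 4 contain the same atoms. The finding of a 28-fold higher number from compound 3 to compound 4 (1.45 log units; beyond the scatter) in this assay shows that the arrangement of chloro and methyl on this phenyl ring matters by itself, with no atom gained or lost. The same two substituents can therefore give either the lowest or the highest number in the set, so having them on the ring does not by itself give strong inhibition. The 4-chloro-3-methylphenyl group also falls behind both other groups, with a 2.6-fold higher number from compound 2 to compound 4 (0.41 log units; beyond the scatter) and a 4.1-fold higher number from compound 1 to compound 4 (0.61 log units; beyond the scatter), which makes compound 4 the least potent of the four.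

These compounds leave open whether chloro or methyl accounts for more of the difference, a question that 2-chlorophenyl, 2-methylphenyl or 2,6-dimethylphenyl at this place could help answer. No measurement available here explains the difference between the two arrangements.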